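Methoxycarbonyl for ethyl in a pyridyl ether series

A few compounds are considered here, and "the series" means these few. Any claim that something is new, unique, unknown or untested is made for them only; others in the source may bear on it.

Measured compounds:
compound 1 `CN1CCC[C@H]1COc1cccnc1Br` 451 nM
compound 2 `CCc1cncc(OC[C@@H]2CCCN2C)c1` 0.32 nM
compound 3 `CN1CCC[C@H]1COc1cc(Br)c[n+]([O-])c1` 34.8 nM

In an assay on membranes from brain for displacement of a labelled ligand from Neuronal acetylcholine receptor; alpha4/beta2 (Rattus norvegicus) (on this read-out higher numbers stand for weaker inhibition and lower numbers for stronger inhibition), compound 2 gives the lowest of the three numbers; compound 3 is nearest to it and compound 1 furthest, both gaps beyond the scatter, so compound 2 is the most potent of the three on this read-out.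

Compound 4 `COC(=O)c1cncc(OC[C@@H]2CCCN2C)c1` is not yet measured. It differs from compound 2 by methoxycarbonyl in place of ethyl on an aromatic carbon. Among the measured compounds shown here, no measured pair shows this change, so the size of the step is uncertain. A step toward weaker inhibition, beyond the scatter, is expected, since compound 2 at 0.32 nM leaves much room in that direction.

For compound 4 the estimate in this assay is 5 nM, within 1 nM to 30 nM. This estimate corresponds to an expected step of a 16-fold higher number from compound 2 to compound 4 (1.19 log units; beyond the scatter).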

Compound 4, inhibition constant: 1.45 nM
Beside the measured number, compound 4's estimate is 3.4-fold (0.54 log units) above it, and the stated range covers the measured number.
By their numbers in this assay, from the lowest: compound 2; then compound 4; then compound 3; then compound 1.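

On an aromatic carbon two atoms from the ring nitrogen, methoxycarbonyl in place of ethyl gives only a modest loss in this assay, a 4.5-fold higher number from compound 2 to compound 4 (0.66 log units; beyond the scatter), even though the entering group is larger and brings hydrogen-bond acceptors that ethyl lacks. Compound 4 therefore keeps a low number at 1.45 nM in this assay, so this position accepts the ester while ethyl remains ahead beyond the scatter. Nothing on hand explains the size of this step.

As far as these compounds go, whether a carboxylic acid, a primary amide or a longer ester such as ethoxycarbonyl at this position would stay close to compound 4 remains open. Also open, from the compounds shown here alone, is whether the same change would cost as little at another place on the ring.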